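The compounds below may be only part of what the source reports. "The series", "measured", "known", "first", "only" and "open" are said of these compounds alone.

Of the compounds shown here, three have so far been measured in an assay on HEK293 cells for agonist activity at transient receptor potential cation channel subfamily M member 8 (Homo sapiens), read by fluorescence and calcium flux, with a stated time of 15 min; on this read-out lower numbers stand for an effect already at smaller amounts and higher numbers for an effect only at larger amounts of compound. Compound 1 `CCN(Cc1cccs1)C(=O)COc1ccc2c(c1)CCC2` gives 0.8 nM in this assay. Compound 3 `O=C(COc1ccc2c(c1)CCC2)N(Cc1cccs1)c1ccn[nH]1` shares its core with compound 1. In this assay compound 3 gives 0.001 nM. The two differ in a single place: ethyl in place of 1H-pyrazol-5-yl on an amide-type nitrogen. That change produced an 800-fold higher number from compound 3 to compound 1 (2.90 log units; beyond the scatter).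

Compound 2 `Cc1ccc(/C=C/C(=O)N(Cc2cccs2)c2ccn[nH]2)cc1` is built on another core; the difference between the two cores is not broken down here. In this assay compound 2 gives 0.004 nM, a number that stands between those of compound 3 and compound 1.

Compound 4 `CCN(Cc1cccs1)C(=O)/C=C/c1ccc(C)cc1` has not yet been measured. It differs from compound 2 in one place: ethyl in place of 1H-pyrazol-5-yl on an amide-type nitrogen. The place is described in the same words for both pairs, so this is the same change as the one already seen, and it occurs twice among these four compounds. Because the earlier change gave an 800-fold higher number from compound 3 to compound 1 (2.90 log units; beyond the scatter), a step of similar size is expected now, a 750-fold higher number from compound 2 to compound 4 (2.88 log units; beyond the scatter). The expected value for compound 4 in this assay is 3 nM, with a likely range from 0.6 nM to 15 nM.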

Compound 4, half-maximal effective concentration: 2 nM
Compound 4: middle estimate off by 1.5-fold (0.18 log units), on the high side; the measured number falls inside the stated range.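

In this assay, putting ethyl in place of 1H-pyrazol-5-yl on the amide-type nitrogen gives a 500-fold higher number from compound 2 to compound 4 (2.70 log units; beyond the scatter) on the second core as well, and the step on each core is about the same size: the same change on two cores in this assay, an 800-fold higher number (2.90 log units; beyond the scatter) from compound 3 to compound 1 and a 500-fold higher number (2.70 log units; beyond the scatter) from compound 2 to compound 4, 1.6-fold (0.20 log units) apart, within the scatter of two such steps.

For these two cores, then, the size of the step hardly depends on the rest of the molecule, and the earlier step was a useful guide to the new one. Going by these compounds alone, two cores are only two examples, however, so this does not show that the same step would appear on a third core, and it does not explain why the two groups give such different numbers.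

Only ethyl and 1H-pyrazol-5-yl appear on this nitrogen in the compounds shown, so nothing here tells how a group of another kind would behave there. A longer chain such as butyl, a chain ending in an amine, or a phenyl ring could give a number close to either group's, or one quite different from both.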